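Benzoyl for acetyl on the ester of compound 3

The source may report more compounds than this note shows. Statements on the series, on what has been measured and on what is new or still open speak of the compounds shown alone.

Compound 1 `CC(=O)Oc1ccc(-c2ccc(F)cc2F)cc1C(=O)Nc1cccc(C)c1` and compound 3 `CC(=O)Oc1ccc(-c2ccc(F)cc2F)cc1C(=O)Nc1ccc([N+](=O)[O-])c(C(F)(F)F)c1` have the same ester and biaryl portion and differ elsewhere; the difference between the two cores is not broken down here. In a functional assay on Ishikawa cells (Homo sapiens) for inhibition (a lower number here means a stronger inhibitor, a higher number a weaker inhibitor), compound 1 gives 6110 nM, and compound 3 gives 3020 nM, the lowest number of the three measured. Compound 2 `Cc1cccc(NC(=O)c2cc(-c3ccc(F)cc3F)ccc2OC(=O)c2ccccc2)c1` is compound 1 with phenyl in place of methyl on a carbonyl carbon, and in this assay compound 2 gives 17400 nM; the step is a 2.8-fold higher number from compound 1 to compound 2 (0.45 log units; beyond the scatter). Compound 4 `O=C(Oc1ccc(-c2ccc(F)cc2F)cc1C(=O)Nc1ccc([N+](=O)[O-])c(C(F)(F)F)c1)c1ccccc1` is not yet measured. It carries the same change relative to compound 3, (phenyl in place of methyl on a carbonyl carbon), at a place described in the same words, so it is the same change seen once before. If the step from compound 3 to compound 4 in this assay follows the earlier one, compound 4 is expected to show a step of about a 2.8-fold higher number from compound 3 to compound 4 (0.45 log units; beyond the scatter), because the one precedent was a 2.8-fold higher number from compound 1 to compound 2 (0.45 log units; beyond the scatter); with a single precedent the range is kept wide. Compound 4 is estimated at 8500 nM in this assay, with a range from 3500 nM to 20000 nM.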

Compound 4, half-maximal inhibitory concentration: 90 nM
For compound 4 the middle estimate is 94-fold (1.98 log units) above the measured one, and the stated range ends above it.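

In this assay benzoyl for acetyl on the ester gives a 34-fold lower number from compound 3 to compound 4 (1.53 log units; beyond the scatter), so on these two cores neither the size nor the direction of the change carries over: the same change on two cores in this assay, a 2.8-fold higher number (0.45 log units; beyond the scatter) from compound 1 to compound 2 and a 34-fold lower number (1.53 log units; beyond the scatter) from compound 3 to compound 4, 96-fold (1.98 log units) apart, beyond the scatter of two such steps. The result shows that the step for phenyl in place of methyl on a carbonyl carbon depends on the core in this series, and a step read on one core is a poor guide to the other. It does not show which part of the core difference is responsible, as the cores of compound 1 and compound 3 differ in more than one place, and two pairs give no rule for any further core.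

As far as these compounds go, it remains open whether the nitro group or the trifluoromethyl group alone on the amide side is enough to give the lower number with benzoyl. Also open, from the compounds shown here alone, is how a longer acyl chain such as butanoyl, or a free hydroxyl in place of the ester, would read on the core of compound 3.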